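Para substituent swap on the phenylpiperazine: methoxy to cyano

The compounds below may be only part of what the source reports. "The series", "measured", "known", "first", "only" and "open" are said of these compounds alone.

Of the compounds shown here, three with a shared core have been measured in a functional assay on MGC-803 cells (Homo sapiens) for antiproliferative activity, read by CCK-8 assay, with a stated time of 72 h, tested at 2 uM; a lower number here means a weaker effect, a higher number a stronger effect of the compound at the concentration tested. Compound 1 `Nc1ccccc1NC(=O)c1ccc(CSC(=S)N2CCN(Cc3ccccn3)CC2)cc1` gives 23.4%, compound 2 `Nc1ccccc1NC(=O)c1ccc(CSC(=S)N2CCN(c3ccccc3)CC2)cc1` gives 42.3%, and compound 3 `COc1ccc(N2CCN(C(=S)SCc3ccc(C(=O)Nc4ccccc4N)cc3)CC2)cc1` gives 25.3%. Compound 3 therefore stands second highest of the three, within the scatter of compound 1 and beyond it only against compound 2, a difference captured by a number 17 percentage points lower from compound 2 to compound 3 (beyond the scatter). Compound 4 `N#Cc1ccc(N2CCN(C(=S)SCc3ccc(C(=O)Nc4ccccc4N)cc3)CC2)cc1` differs from compound 3 in one place: cyano in place of methoxy on an aromatic carbon. Among the measured compounds shown here, no measured step exchanges a cyano group for a methoxy group, so the only step that bears on this change is the one introducing methoxy, a number 17 percentage points lower from compound 2 to compound 3 (beyond the scatter), and the direction for cyano is unknown. He estimates compound 4 at 35%, expected to lie between 18% and 55%, which would mean a step of a number 9.7 percentage points higher from compound 3 to compound 4 (within the scatter).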

Compound 4, a percentage reported as inhibition, at one concentration (the size of the read-out at that concentration, not a potency): 34.5%
Compound 4: the middle estimate sits 0.5 percentage points above what was measured, within the range that was stated.
By their numbers in this assay, from the lowest: compounds 1, 3, 4 and 2 (each within the scatter of the next, the first and the last beyond it).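

On an aromatic carbon para to a large group in this assay, cyano does not repeat the loss seen with methoxy: the step from the unsubstituted phenyl (a number 7.8 percentage points lower from compound 2 to compound 4 (within the scatter)) stays within the scatter, as does the swap of methoxy for cyano (a number 9.2 percentage points higher from compound 3 to compound 4 (within the scatter)). The 4-cyanophenyl group also separates from (pyridin-2-yl)methyl on the ring nitrogen (a number 11.1 percentage points higher from compound 1 to compound 4 (beyond the scatter)), which 4-methoxyphenyl did not. No measurement available here accounts for these results. What the compounds shown leave open is how an amine, a carboxylic acid or a fluorine atom would behave at this place.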